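The compounds below may be only part of what the source reports. "The series", "measured", "known", "first", "only" and "open" are said of these compounds alone.

Measured compounds:
compound 1, `O=C(O)c1cccc([C@H]2C[C@@H]2c2ccc(OCc3c(-c4c(Cl)cccc4Cl)noc3C3CC3)cc2Cl)c1`: 101%
compound 2, `O=C(NCCS(=O)(=O)O)c1ccc(C2CC2c2ccc(OCc3c(-c4c(Cl)cccc4Cl)noc3C3CC3)cc2Cl)cc1`: 98%

Both values come from an assay on isolated protein for agonist activity at Bile acid receptor (Homo sapiens), read by FRET; a higher number here means a larger maximal response, a lower number a smaller maximal response. Compound 1 holds the highest of the two numbers; compound 2 lies a few points lower, within the scatter, so the two cannot be ordered against each other. Among the measured compounds shown here, no pair of measured compounds that differ in one place is available, so no measured step exists in this set.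

Compound 3, `O=C(O)c1cccc([C@@H]2C[C@H]2c2ccc(OCc3c(-c4c(Cl)cccc4Cl)noc3C3CC3)cc2Cl)c1`, is to be measured in this assay. Relative to compound 1 the change is: the two compounds have the same atoms and bonds and differ only in configuration as drawn: 2 of 2 stereo elements differ (all stereocentres are inverted: mirror images); a stereocentre at a saturated ring carbon is drawn S in compound 1 and R in compound 3; a stereocentre at a saturated ring carbon is drawn S in compound 1 and R in compound 3. For the measured compounds named here, the set contains no measured pair of mirror images, so the size of such a step is not known from these data. A downward step beyond the scatter is expected, of moderate size, with wide uncertainty. The expected value for compound 3 is 80%, between 35% and 105%. The step of a number 21 percentage points lower from compound 1 to compound 3 (beyond the scatter) is an estimate, not a measurement.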

Compound 3, largest response reached (reported as efficacy), in percent of the reference or control that the assay uses: 100%
Compound 3: the middle estimate sits 20 percentage points below what was measured, and the stated range covers the measured number.
By their numbers in this assay, from the lowest: compounds 2, 3 and 1 (each within the scatter of the next).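

In this assay, among the compounds shown here, inverting both stereocentres at the saturated ring carbons gives a number 1 percentage points lower from compound 1 to compound 3 (within the scatter) and so adds the only measured step in this set. The comparison isolates configuration, with nothing else changing between the two structures: the fact that compounds 1 and 3 differ only in the configuration as drawn. For this pair, the mirror-image change therefore leaves the maximal response without a difference that can be read, although a maximal response alone does not show the concentration needed to reach it.

Still open, going by these compounds, is the effect of inverting only one of the two stereocentres, a change that would give a compound that is not a mirror image of compound 1. Also open, on these data alone, is whether an amine or a primary amide in place of the carboxylic acid of compound 1 would retain the maximal response.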